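The compounds below may be only part of what the source reports. "The series", "measured", "known", "first", "only" and "open" are said of these compounds alone.

Measured compounds in a functional assay on MCF7 cells (Homo sapiens) for cytotoxicity, read by MTT assay, with a stated time of 24 h; a higher number here means a weaker inhibitor, a lower number a stronger inhibitor:
Compound 1, `CCOC(=O)c1sc(-c2nc3ccccc3n2C(C)C)nc1C` — in this assay compound 1 gives > 20000 nM, a limit of the assay and not a number.
Compound 2, `CCOC(=O)c1csc(-c2nc3ccccc3n2C)n1` — in this assay compound 2 gives > 20000 nM, likewise a limit.
Compound 3, `CCOC(=O)c1csc(-c2nc3ccccc3n2Cc2ccccc2)n1` — in this assay compound 3 gives > 20000 nM, again a limit.

Compound 3 therefore stands nowhere on a scale: its value is a limit, and the two other values shown are limits as well, so no order among the three compounds can be read. Within the data shown here, the only step that joins two measured compounds in one place is a step that the two limits leave unreadable from compound 2 to compound 3; it stays unreadable because the limit of > 20000 nM in this assay, at which 3 of the 3 values shown sit, covers both of its ends.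

Compound 4, `CCOC(=O)c1csc(-c2nc3ccccc3n2CC)n1`, is not yet measured. It differs from compound 3 in one place: methyl in place of phenyl on a saturated chain carbon bound to an aromatic nitrogen. The step that bears on this change, a step that the two limits leave unreadable from compound 2 to compound 3, gives no size and no direction, and with the limit of > 20000 nM in this assay, at which 3 of the 3 values shown sit, holding for every value shown there is no evidence that any change at this position moves the read-out into the measurable range. The expected outcome for compound 4 is thus another limit, and the step from compound 3 to compound 4 is estimated at a step that the limit leaves unreadable from compound 3 to compound 4. Compound 4 is expected to give 35000 nM, within a range of 12000 nM to 120000 nM.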

Compound 4, half-maximal inhibitory concentration: > 20000 nM
Compound 4: no number, only a limit; the forecaster's own chance of this, stated with the estimate: 85%; the middle value is on the limit's open side.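

The steps from compound 3 to compound 4 and from compound 2 to compound 4 cannot be read, because their ends are limits and not numbers in this assay: the limit of > 20000 nM in this assay, at which 4 of the 4 values shown sit.

The compounds shown leave open whether any change, on the saturated chain carbon bound to an aromatic nitrogen or elsewhere, gives a measurable value in this assay, and how these compounds rank.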